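The compounds below may be only part of what the source reports. "The series", "measured", "known", "first", "only" and "open" are said of these compounds alone.

Working notes on the series. Three compounds share one core and have numbers in a functional assay on HL-60 cells (Homo sapiens) for inhibition, with a stated time of 48 h; a higher number here means a weaker inhibitor, a lower number a stronger inhibitor. Compound 1 `CCOC(=O)C1=C(N)Oc2ccc(-c3cc(OC)cc(OC)c3)cc2C1CC(=O)c1ccccc1` gives 109000 nM in this assay. Compound 2 `C#CCOC(=O)C1=C(N)Oc2ccc(-c3cc(OC)cc(OC)c3)cc2C1CC(O)c1ccccc1` gives 100000 nM in this assay. Compound 3 `C#CCOC(=O)C1=C(N)Oc2ccc(-c3cc(OC)cc(OC)c3)cc2C1CC(=O)c1ccccc1` gives 7300 nM in this assay, the lowest of the three numbers; its nearest neighbour is compound 2 and its furthest is compound 1. The two steps into compound 3 are both large: a 15-fold lower number from compound 1 to compound 3 (1.17 log units; beyond the scatter) and a 14-fold lower number from compound 2 to compound 3 (1.14 log units; beyond the scatter).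

Compound 4 `C#CCOC(=O)C1=C(N)Oc2ccc(-c3cc(OC)cc(OC)c3)cc2C1CC(O)CCC` is not yet measured. The change from compound 3 is 1-hydroxybutyl in place of benzoyl on a saturated chain carbon bound to a saturated ring carbon. The step from compound 2 to compound 3 bears on it directly, since compound 4 carries a hydroxy group where compound 3 carries a carbonyl, as compound 2 does. For the measured compounds named here, no measured step shows the exchange of the six-membered aromatic ring for a chain, so that part is open. A step in this assay of about the size of the step from compound 2 to compound 3, but in the opposite direction, is therefore expected, a 14-fold higher number from compound 3 to compound 4 (1.14 log units; beyond the scatter). The estimate for compound 4 in this assay is 100000 nM, with a range from 30000 nM to 300000 nM.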

Compound 4, half-maximal inhibitory concentration: 46600 nM
Beside the measured number, compound 4's estimate is 2.1-fold (0.33 log units) above it, and the stated range covers the measured number.
By their numbers in this assay, from the lowest: compound 3; then compound 4; then compounds 2 and 1 (each within the scatter of the next).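

With the hydroxy group kept, propyl in place of phenyl gives the first reading of the aromatic ring against a chain at this position: a 2.1-fold lower number from compound 2 to compound 4 (0.33 log units; beyond the scatter) in this assay, so among these alcohols the phenyl is not needed for the lower number. The exchange of benzoyl for 1-hydroxybutyl still costs activity, with a 6.4-fold higher number from compound 3 to compound 4 (0.81 log units; beyond the scatter), and compound 3 keeps the lowest number of the series. No supporting evidence bears on why either step takes this size.

The step from benzoyl to 1-hydroxybutyl changes both the carbonyl and the ring, and the compounds shown do not separate the two. As far as these compounds go, a butanoyl group would show whether a chain keeps the gain seen with the carbonyl, and a longer chain or an amine in place of the hydroxy group remains open.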